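This account rests on a few compounds, and the source may have more. Where it says the series, first, only, none or still open, it means among the compounds named here.

Measured compounds:
compound 1 `CC(C)c1ccccc1OS(=O)(=O)c1cccc(NC(=O)CCl)c1` — 4500 nM
compound 2 `CC(=O)Nc1ccc(S(=O)(=O)Oc2ccccc2C(C)C)cc1` — 23000 nM
compound 3 `CC(=O)Nc1ccc(S(=O)(=O)Oc2ccccc2I)cc1` — 23000 nM

All three were tested in a functional assay on HT-29 cells (Homo sapiens) for antiproliferative activity, read by sulforhodamine B assay, with a stated time of 48 h; a lower number here means a stronger inhibitor, a higher number a weaker inhibitor. Compound 2 stands level with compound 3 at the digits shown, and the two of them share the highest number of the set; compound 1 gives the lowest value, a gap that lies beyond the scatter. Among the measured compounds shown here, the one measured step, no change at the digits printed from compound 2 to compound 3 (within the scatter), concerns an exchange on an aromatic carbon of the sulfonate ester side and leaves the acetamido group untouched.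

Compound 4 `CC(C)C(=O)Nc1ccc(S(=O)(=O)Oc2ccccc2C(C)C)cc1` differs from compound 2 in the acyl group alone: isopropyl in place of methyl on a carbonyl carbon. For the measured compounds named here, no measured step touches this carbonyl carbon, so nothing in the present numbers reports directly on such a change. Going by the values given here, the only available comparison, from compound 2 to compound 3, shows a different exchange elsewhere in the molecule that left this assay unchanged, and the acetamido compounds sit together at the weak end. On that basis the step from compound 2 to compound 4 is expected to be small, a 1.2-fold lower number from compound 2 to compound 4 (0.06 log units; within the scatter), with no direction favoured beyond the scatter. Compound 4 is therefore estimated at 20000 nM in this assay, within a range of 8000 nM to 50000 nM.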

Compound 4, half-maximal inhibitory concentration: 14000 nM
Compound 4: the middle estimate sits 1.4-fold (0.15 log units) above what was measured, within the range that was stated.
By their numbers in this assay, from the lowest: compound 1; then compounds 4, 2 and 3 (each within the scatter of the next).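

In this assay, among the compounds shown here, the exchange of methyl for isopropyl on a carbonyl carbon gives a 1.6-fold lower number from compound 2 to compound 4 (0.22 log units; within the scatter), and this is the first reading at this position, which the earlier compounds did not touch. The acetyl group of compound 2 can therefore give way to isopropylcarbonyl in compound 4 without a change that can be told apart from repeat measurements, so this single exchange does not establish a gain or a loss in this assay. The material at hand offers no independent measurement that would account for this outcome.

The compounds shown leave open whether a longer chain, a phenyl ring, an amine or a carboxylic acid on this carbonyl carbon would give a step beyond the scatter, since methyl and isopropyl are the only two groups compared there with everything else held the same. From the compounds shown here alone, it also remains open whether the exchange of acetamido for (isopropylcarbonyl)amino would read the same in compound 3, which carries iodo in place of the isopropyl on the aromatic carbon.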